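Chloro on a Phenyl Ring Across Two Cores

The compounds below may be only part of what the source reports. "The series", "measured", "known", "first", "only" and "open" are said of these compounds alone.

compound 1 `Clc1ccc(-c2n[nH]cc2N2CCCNCC2)cc1`: 498 nM
compound 2 `c1ccc(-c2n[nH]cc2N2CCCNCC2)cc1`: 2100 nM
compound 3 `c1ccc(-c2n[nH]cc2N2CCNCC2)cc1`: > 10000 nM

These three compounds were tested in an assay on isolated protein for binding affinity to 5-hydroxytryptamine receptor 3A (Homo sapiens); a lower number here means a stronger inhibitor, a higher number a weaker inhibitor. Compound 2 gives 2100 nM, and the change to compound 1, (chloro in place of hydrogen on an aromatic carbon), brings a 4.2-fold lower number from compound 2 to compound 1 (0.62 log units; beyond the scatter). Compound 3 gives > 10000 nM, which is a limit of the assay rather than a number (the limit of > 10000 nM in this assay, at which 1 of the 3 values shown sits). The difference between the core of compound 3 and the core of compound 2 is not broken down here. Compound 4 `Clc1ccc(-c2n[nH]cc2N2CCNCC2)cc1` has not yet been measured; it differs from compound 3 by chloro in place of hydrogen on an aromatic carbon, the same change as between compound 2 and compound 1. The expected step is an at least 2.5-fold lower number from compound 3 to compound 4 (0.39 log units; beyond the scatter), resting on a 4.2-fold lower number from compound 2 to compound 1 (0.62 log units; beyond the scatter) seen only once. Compound 4 is therefore expected to reach about 4000 nM, somewhere from 1000 nM to 15000 nM. Whether the measurement bears this out remains to be seen.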

Compound 4, inhibition constant: 1790 nM
Compound 4: middle estimate off by 2.2-fold (0.35 log units), on the high side, and the stated range covers the measured number.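

In this assay, chloro in place of hydrogen on the aromatic ring lowers the number on this second core too, with an at least 5.5-fold lower number from compound 3 to compound 4 (0.74 log units; beyond the scatter). So the direction of the change carries over between these two cores, but whether its size also carries over cannot be settled: the same change on two cores in this assay, a 4.2-fold lower number (0.62 log units; beyond the scatter) from compound 2 to compound 1 and an at least 5.5-fold lower number (0.74 log units; beyond the scatter) from compound 3 to compound 4; the limit leaves it open whether they differ. Compound 3 gives > 10000 nM, which is a limit of the assay and not a number: the limit of > 10000 nM in this assay, at which 1 of the 4 values shown sits.

Chloro is the only group shown on this ring, so it remains open whether fluoro, bromo or methoxy in the same place would lower the number as well. From the compounds shown here alone, it also remains open whether the chloro change would do the same on any core beyond these two.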